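Compound 4: a larger group on the carbonyl carbon

This account rests on a few compounds, and the source may have more. Where it says the series, first, only, none or still open, it means among the compounds named here.

- Compound 1 (`O=C(Cc1c[nH]c2ccccc12)N/N=C1\C[C@@H](c2ccc(O)cc2)Oc2cc(O)cc(O)c21`): >= 11300 nM, a limit
- Compound 2 (`COc1cc(O)c2c(c1)O[C@H](c1ccc(O)cc1)C/C2=N\NC(=O)c1cccs1`): 9400 nM
- Compound 3 (`COc1cc(O)c2c(c1)O[C@H](c1ccc(O)cc1)C/C2=N\NC(=O)c1ccco1`): >= 11300 nM, a limit

These values come from a functional assay on L5178Y cells (Mus musculus) for inhibition, read by MTT assay, with a stated time of 24 h; a higher number here means a weaker inhibitor, a lower number a stronger inhibitor. Compound 3 has no exact number, only the limit >= 11300 nM. Compound 4 (`COc1cc(O)c2c(c1)O[C@H](c1ccc(O)cc1)C/C2=N\NC(=O)Cc1c[nH]c2ccccc12`) carries (1H-indol-3-yl)methyl in place of furan-2-yl on a carbonyl carbon. Within the data shown here, the only measured step at that carbon, an at least 1.2-fold higher number from compound 2 to compound 3 (0.07 log units; that floor lies within the scatter), is small. Compound 1 already carries (1H-indol-3-yl)methyl there and gives only the limit >= 11300 nM. No change beyond the scatter is therefore expected in this assay, in either direction. The expected step is a step that the limit leaves unreadable from compound 3 to compound 4. Compound 4 is estimated at 12000 nM, with an expected range of 6000 nM to 25000 nM.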

Compound 4, half-maximal inhibitory concentration: >= 11300 nM
Compound 4 ended at the assay's limit; the forecaster's own chance of this, stated with the estimate: 55%; the middle value is on the limit's open side.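

In this assay compound 4 gives >= 11300 nM, a limit, so even the larger (1H-indol-3-yl)methyl on the carbonyl carbon yields no exact value. Set against thiophen-2-yl, the same change gives an at least 1.2-fold higher number from compound 2 to compound 4 (0.07 log units; that floor lies within the scatter). The steps to compound 4 from compound 3 and from compound 1 cannot be read, because both compounds in each pair sit at the same value: the limit of >= 11300 nM in this assay, at which 3 of the 4 values shown sit.

Still open, on these data alone, is whether another group on this carbonyl carbon, such as an aminoethyl chain or a phenyl ring, would give a number clearly lower than that of compound 2.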